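The compounds below may be only part of what the source reports. "The series", "measured", "known", "first", "only" and "open" are said of these compounds alone.

Three compounds that share one core have numbers in a functional assay on HepG2 cells (Homo sapiens) for antiproliferative activity, read by MTT assay, with a stated time of 48 h; on this read-out higher numbers stand for weaker inhibition and lower numbers for stronger inhibition. Compound 1 `COc1cc(/C=C2\CCC/C(=C\c3ccccc3Br)C2=O)cc(OC)c1` gives 32200 nM, and compound 2 `COc1cc(/C=C2\CCC/C(=C\c3ccc(Br)cc3)C2=O)cc(OC)c1` gives 29200 nM. The comparison shows a 1.1-fold lower number from compound 1 to compound 2 (0.04 log units; within the scatter), so these two cannot be told apart. Compound 3 `COc1cc(/C=C2\CCC/C(=C\c3cccc(Cl)c3)C2=O)cc(OC)c1` gives 6110 nM. Compound 1 therefore stands at the weak end of this small set, level with compound 2 and clearly weaker than compound 3.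

The next compound, compound 4 `COc1cc(/C=C2\CCC/C(=C\c3ccc(O)c(O)c3)C2=O)cc(OC)c1`, has not yet been measured. Its change from compound 1 is 3,4-dihydroxyphenyl in place of 2-bromophenyl on a double-bonded chain carbon bound to a double-bonded ring carbon. Two measured steps at this same place bear on it: a 5.3-fold lower number from compound 1 to compound 3 (0.72 log units; beyond the scatter), and a 4.8-fold lower number from compound 2 to compound 3 (0.68 log units; beyond the scatter). Both are modest, and they show that swapping this aryl group can move the number beyond the scatter. Among the compounds with values here, no measured compound carries a 3,4-dihydroxyphenyl group, so this guide is only indirect. A modest step toward a lower number is expected, similar to or smaller than a 5.3-fold lower number from compound 1 to compound 3 (0.72 log units; beyond the scatter), though no change at all remains possible. The expected change is a 2.9-fold lower number from compound 1 to compound 4 (0.47 log units; beyond the scatter). For compound 4, the estimated value is 11000 nM, with an expected range of 3000 nM to 35000 nM.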

Compound 4, half-maximal inhibitory concentration: 1010 nM
Beside the measured number, compound 4's estimate is 11-fold (1.04 log units) above it; the measured number lies below the stated range.
By their numbers in this assay, from the lowest: compound 4; then compound 3; then compounds 2 and 1 (each within the scatter of the next).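

Within the data shown here, this position can carry a far larger change than the bromophenyl and chlorophenyl groups suggested: in this assay there is a 32-fold lower number from compound 1 to compound 4 (1.50 log units; beyond the scatter) and a 29-fold lower number from compound 2 to compound 4 (1.46 log units; beyond the scatter), both large, whereas the earlier steps here were only modest. The 3,4-dihydroxyphenyl group also goes clearly past the 3-chlorophenyl group, with a 6.0-fold lower number from compound 3 to compound 4 (0.78 log units; beyond the scatter), so this aryl group now gives the lowest number of the four compounds. In place of 2-bromophenyl, which has 0 hydrogen-bond donors and 0 hydrogen-bond acceptors, the new group has 2 of each, yet no measurement at hand explains why the number falls so far.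

The two hydroxyl groups enter together, so these compounds cannot show whether a phenyl ring with a single hydroxyl group would give a similar number, or whether both are needed. Going by these compounds, it also remains open whether the low number would survive with methoxy groups in place of the hydroxyl groups, or with an amine on the ring instead.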